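The compounds below may be only part of what the source reports. "The series", "measured", "known", "first", "only" and "open" are said of these compounds alone.

Compound 2 `CCCCCc1cc2ccccc2nc1-c1cn(-c2ccc(F)cc2)nn1` is the reference point here. In a functional assay on HeLa cells (Homo sapiens) for cytotoxicity, read by MTT assay, with a stated time of 24 h (a lower number here means a stronger inhibitor, a higher number a weaker inhibitor), compound 2 gives only a limit of the assay, > 100 ug/mL, and no number. Compound 1 `Cc1cc2ccccc2nc1-c1cn(-c2ccc(F)cc2)nn1` carries a methyl chain where compound 2 carries pentyl. In this assay compound 1 likewise reaches only a limit, namely > 100 ug/mL. Compound 3 `CCCCCCCCCCn1cc(-c2nc3ccccc3cc2CCCCC)nn1`, with a decyl chain in place of the 4-fluorophenyl group on the ring nitrogen, also shows only a limit in this assay, > 100 ug/mL. The step that the two limits leave unreadable from compound 1 to compound 2 therefore cannot be read, and the same holds for a step that the two limits leave unreadable from compound 2 to compound 3; all values stand at the limit of > 100 ug/mL in this assay, at which 3 of the 3 values shown sit.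

Compound 4 `CCCc1cc2ccccc2nc1-c1cn(-c2ccc(F)cc2)nn1` is the untested member. Its change from compound 2 is hydrogen in place of ethyl on a saturated chain carbon, three bonds along the chain from an aromatic carbon, a shortening of the chain. Neither measured step gives a readable size that bears on this change, and no value shown lies anywhere but at the limit. The step expected, a step that the limit leaves unreadable from compound 2 to compound 4, amounts to no change beyond the scatter. Compound 4 is estimated at 150 ug/mL, within a range from 60 ug/mL to 400 ug/mL.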

Compound 4, half-maximal inhibitory concentration: > 100 ug/mL
Compound 4: a limit, no number; the forecaster's own chance of this, stated with the estimate: 80%; the middle value does not contradict the limit.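

In this assay compound 4 also gives only a limit, > 100 ug/mL and no number, so its steps to compound 1 and compound 2 cannot be read. The compounds shown leave open how chain length or the group on the ring nitrogen affects cytotoxicity, since none gives a number: the limit of > 100 ug/mL in this assay, at which 4 of the 4 values shown sit.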